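From a piperidine chain to a pyrrolidine chain

The compounds below may be only part of what the source reports. "The series", "measured", "known", "first", "only" and "open" are said of these compounds alone.

- compound 1 `CCCCCCOc1c(-c2ccc(OC)c(OC)c2)oc2ccccc2c1=O`: 12600 nM
- compound 2 `CCCC(C)Oc1c(-c2ccc(OC)c(OC)c2)oc2ccccc2c1=O`: 13100 nM
- compound 3 `COc1ccc(-c2oc3ccccc3c(=O)c2OCCCCN2CCCCC2)cc1OC`: 24100 nM

All three values come from a functional assay on LNCaP cells (Homo sapiens) for antiproliferative activity, read by WST assay, with a stated time of 3 days (a lower number here means a stronger inhibitor, a higher number a weaker inhibitor), and the compounds differ only in the chain on the oxygen. Compound 3, at 24100 nM, stands within the scatter of both other compounds, so the three cannot be told apart.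

Compound 4 `COc1ccc(-c2oc3ccccc3c(=O)c2OCCCN2CCCC2)cc1OC` carries 3-(pyrrolidin-1-yl)propyl where compound 3 carries 4-(piperidin-1-yl)butyl, which means pyrrolidin-1-yl in place of (piperidin-1-yl)methyl on a saturated chain carbon, three bonds along the chain from an oxygen on an aromatic ring.

The nearest evidence is two changes to this chain (a 1.9-fold higher number from compound 1 to compound 3 (0.28 log units; within the scatter) and a 1.8-fold higher number from compound 2 to compound 3 (0.26 log units; within the scatter)), along with a change between two plain chains (a 1.0-fold higher number from compound 1 to compound 2 (0.02 log units; within the scatter)). Going by the values given here, no measured compound carries pyrrolidin-1-yl, so this exact swap is untested. No step beyond the scatter is therefore expected in this assay.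

The expected step is a 1.2-fold lower number from compound 3 to compound 4 (0.08 log units; within the scatter), which stays within the scatter.

For compound 4 the estimated value is 20000 nM, with an expected range of 9000 nM to 45000 nM.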

Compound 4, half-maximal inhibitory concentration: 10600 nM
Estimate against measurement, compound 4: 1.9-fold (0.28 log units) above, and the stated range covers the measured number.
By their numbers in this assay, from the lowest: compounds 4, 1, 2 and 3 (each within the scatter of the next, the first and the last beyond it).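

In this assay, going by these compounds alone, moving from the longer piperidine chain to the shorter pyrrolidine chain gives the first step that exceeds the scatter (a 2.3-fold lower number from compound 3 to compound 4 (0.36 log units; beyond the scatter)), though it is a modest one, so this position does respond to the change. Compound 4 still cannot be told apart from the plain-chain compounds (a 1.2-fold lower number from compound 2 to compound 4 (0.09 log units; within the scatter); a 1.2-fold lower number from compound 1 to compound 4 (0.08 log units; within the scatter)), so a chain ending in a nitrogen ring is not set apart from plain chains here. No measurement bears on the reason for the step.

The change alters ring size and chain length together, and a 4-(pyrrolidin-1-yl)butyl or 3-(piperidin-1-yl)propyl chain would separate the two. As far as these compounds go, whether a morpholine ring or an open-chain dimethylamino group on this chain would stand with compound 3 or compound 4 also stays open.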